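The source may hold more compounds than are shown below. What is called first, only, known or untested is meant among the compounds shown, and "the series" means these compounds.

Values measured so far in a functional assay (trachea) with Cavia porcellus as the target (on this read-out lower numbers stand for stronger inhibition and higher numbers for weaker inhibition), are these:

compound 1 `CC(C)n1nc(-c2cccnc2)c2ccccc2c1=O` at 3090 nM
compound 2 `O=c1c2ccccc2c(-c2cccnc2)nn1C1CCCC1` at 2750 nM
compound 3 `O=c1c2ccccc2c(-c2cccnc2)nn1Cc1cccc(Cl)c1` at 4170 nM

In this assay compound 3 stands at 4170 nM and lies within the scatter of both other compounds, so the three numbers cannot be ranked. Compound 4 (`CCOC(=O)CCCn1nc(-c2cccnc2)c2ccccc2c1=O`) has not yet been measured. The structural change from compound 3 (2-(ethoxycarbonyl)ethyl in place of 3-chlorophenyl on a saturated chain carbon bound to an aromatic nitrogen) puts 2-(ethoxycarbonyl)ethyl in place of 3-chlorophenyl on a saturated chain carbon bound to an aromatic nitrogen.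

Among the compounds with values here, three measured steps bear on this change, since all of them swap the group on that same aromatic nitrogen. They are the cyclopentyl swap (a 1.1-fold lower number from compound 1 to compound 2 (0.05 log units; within the scatter)), the 3-chlorobenzyl swap (a 1.3-fold higher number from compound 1 to compound 3 (0.13 log units; within the scatter)) and the exchange of those two groups (a 1.5-fold higher number from compound 2 to compound 3 (0.18 log units; within the scatter)). Within the data shown here, all three stay within the scatter, so no step of any size or direction is expected beyond it. Among the measured compounds shown here, the data have a limit, however: no measured compound carries 3-(ethoxycarbonyl)propyl on that nitrogen, and the range is therefore kept wide on both sides.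

The expected step is small (a 1.3-fold lower number from compound 3 to compound 4 (0.10 log units; within the scatter)) and stays within the scatter. For compound 4 the estimated value is 3300 nM with an expected range from 1100 nM to 9500 nM in this read-out.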

Compound 4, half-maximal inhibitory concentration: 10000 nM
Estimate against measurement, compound 4: 3.0-fold (0.48 log units) below; measured number above the stated range.
By their numbers in this assay, from the lowest: compounds 2, 1 and 3 (each within the scatter of the next); then compound 4.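

In this assay, within the data shown here, the group on the aromatic nitrogen moves the number beyond the scatter for the first time: isopropyl, cyclopentyl and 3-chlorobenzyl had stayed within the scatter of one another, whereas 3-(ethoxycarbonyl)propyl gives modest steps in all three comparisons (a 3.2-fold higher number from compound 1 to compound 4 (0.51 log units; beyond the scatter); a 3.6-fold higher number from compound 2 to compound 4 (0.56 log units; beyond the scatter); a 2.4-fold higher number from compound 3 to compound 4 (0.38 log units; beyond the scatter)). In the swap of 3-chlorophenyl for 2-(ethoxycarbonyl)ethyl on a saturated chain carbon bound to an aromatic nitrogen, the heavy-atom count stays equal, so that count does not follow the step; the entering group differs instead in having no ring, in its double bond outside aromatic rings and in its hydrogen-bond acceptors, and a single compound cannot separate these differences. No measurement on hand explains why this group gives the higher number.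

The compounds shown leave open whether the ethoxycarbonyl end or the open chain itself goes with the step, a question that a plain pentyl chain, a carboxylic acid or an amide on the same nitrogen would address. They also leave open whether any group at this position, such as an amine-bearing chain, could give a number clearly lower than those of compound 1, compound 2 and compound 3.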